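Shortening a sulfonyl chain at the assay limit

The source may hold more compounds than are shown below. What is called first, only, known or untested is meant among the compounds shown, and "the series" means these compounds.

Compound 1 `CCS(=O)(=O)c1ccc(NC2CCCCC2)c([N+](=O)[O-])c1` carries an ethylsulfonyl group on the shared core. In an assay on cells for inhibition of serine/threonine-protein kinase WNK1 (Homo sapiens), read by luminescence and Kinase-Glo, with a stated time of 2 h (a higher number here means a weaker inhibitor, a lower number a stronger inhibitor), compound 1 reaches only the limit of the assay, giving > 1000000 nM. Compound 3 `O=S(=O)(c1ccc(NC2CCCCC2)cc1)C(Cl)(Cl)Br` likewise gives only the limit, > 1000000 nM, in this assay. Compound 2 `O=[N+]([O-])c1cc(S(=O)(=O)C(Cl)(Cl)Br)ccc1Nc1ccccc1`, the only one of the three with a number, gives 76000 nM in this assay. For the measured compounds named here, compound 1 thus sits at the limit of > 1000000 nM in this assay, at which 2 of the 3 values shown sit, with no measured step joining it to another compound. Compound 4 `CS(=O)(=O)c1ccc(NC2CCCCC2)c([N+](=O)[O-])c1` differs from compound 1 by hydrogen in place of methyl on a saturated chain carbon bound to a sulfonyl sulfur. Given that compound 1 stands at the limit of > 1000000 nM in this assay, at which 2 of the 3 values shown sit, the expected step is a step that the limit leaves unreadable from compound 1 to compound 4, hardly beyond the scatter. Compound 4 is therefore expected to give about 1500000 nM in this assay, between 300000 nM and 5000000 nM, most probably again only as a limit.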

Compound 4, half-maximal inhibitory concentration: > 1000000 nM
Compound 4 ended at the assay's limit; the forecaster's own chance of this, stated with the estimate: 80%; the middle value is on the limit's open side.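

Compound 1 and compound 4 both give only a limit in this assay, so no step between them can be read: the limit of > 1000000 nM in this assay, at which 3 of the 4 values shown sit.

The compounds shown leave open whether ethylsulfonyl to methylsulfonyl changes inhibition at all.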